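A few compounds are considered here, and "the series" means these few. Any claim that something is new, unique, unknown or untested is made for them only; others in the source may bear on it.

Measured compounds:
- compound 1, `N#CC1=C(N)N(c2ccc(S(N)(=O)=O)cc2)C2=C(C(=O)CCC2)C1/C=C/c1ccccc1`: 10%
- compound 2, `COc1ccc(C2C(C#N)=C(N)N(c3ccc(S(N)(=O)=O)cc3)C3=C2C(=O)CCC3)cc1`: 50%
- compound 3, `N#CC1=C(N)N(c2ccc(S(N)(=O)=O)cc2)C2=C(C(=O)CCC2)C1c1ccc([N+](=O)[O-])cc1`: 80%

In a functional assay on Ehrlich cells (Mus musculus) for antiproliferative activity, read by trypan blue exclusion, with a stated time of 2 h, tested at 25 ug/mL (on this read-out lower numbers stand for a weaker effect and higher numbers for a stronger effect at the one concentration tested), compound 3 stands highest of the three, with compound 2 nearest and compound 1 furthest; both gaps lie beyond the scatter, so compound 3 counts as the strongest measured here.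

Compound 4, `COc1ccc(C2C(C#N)=C(N)N(c3ccc(S(N)(=O)=O)cc3)C3=C2C(=O)CCC3)c2ccccc12`, has not been measured. It differs from compound 3 in one place: 4-methoxynaphthalen-1-yl in place of 4-nitrophenyl on a saturated ring carbon.

Going by the values given here, two measured steps bear on this. The step of a number 30 percentage points higher from compound 2 to compound 3 (beyond the scatter) shows that trading methoxy for nitro on the aromatic carbon raised the number modestly; compound 4 returns to methoxy, so a drop of about that size is plausible. Among the compounds with values here, the step of a number 70 percentage points higher from compound 1 to compound 3 (beyond the scatter) shows a large rise when the 4-nitrophenyl replaced 2-phenylethenyl, but no measured pair covers the added second aromatic ring of the naphthalene, so its effect stays unknown.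

Compound 4 is therefore expected to fall below compound 3, with an estimated step of a number 30 percentage points lower from compound 3 to compound 4 (beyond the scatter), giving an expected value of 50%, in a range from 25% to 75%.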

Compound 4, a percentage reported as activity, at one concentration (the size of the read-out at that concentration, not a potency): 10%
Estimate against measurement, compound 4: 40 percentage points above, outside the stated range (below it).
By their numbers in this assay, from the lowest: compounds 1 and 4 (each within the scatter of the next); then compound 2; then compound 3.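

With the methoxy kept, widening 4-methoxyphenyl to 4-methoxynaphthalen-1-yl on this saturated ring carbon gives a number 40 percentage points lower from compound 2 to compound 4 (beyond the scatter) in this assay and so shows that this position responds to the added aromatic ring, not only to the exchange of nitro for methoxy. Replacing 4-nitrophenyl outright gives a number 70 percentage points lower from compound 3 to compound 4 (beyond the scatter) and the comparison with the 2-phenylethenyl compound gives no change at the digits printed from compound 1 to compound 4 (within the scatter) so two quite different groups on this carbon end up level at the low end of the series. Nothing available here explains this loss of activity.

The compounds shown leave open whether 4-nitronaphthalen-1-yl would keep the high number of the nitro compound or share the low number of compound 4. They also leave open how a plain phenyl, a methyl or a 4-aminophenyl group would behave on this carbon.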